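The source may hold more compounds than are shown below. What is called first, only, known or untested is meant among the compounds shown, and "the series" means these compounds.

Measured so far in an assay on isolated protein for inhibition of histone acetyltransferase KAT2B (Homo sapiens), read by fluorescence, with a stated time of 10 min; on this read-out higher numbers stand for weaker inhibition and lower numbers for stronger inhibition:
compound 1 `O=c1c2cc([N+](=O)[O-])cnc2sn1-c1ccc(Oc2ccccc2)cc1` gives 5300 nM
compound 2 `CC(C)CNC(=O)Cn1sc2ccccc2c1=O` gives 10700 nM

Compound 2 stands at the highest of the two numbers. Within the data shown here, its nearest neighbour, compound 1, gives the lower number, and the gap between them lies beyond the usual scatter; no single-site step between the two has been worked out, so nothing more is read into that pair. Compound 3 `O=C(Cn1sc2ccccc2c1=O)NCc1ccccn1` is not yet measured. It differs from compound 2 in one place: pyridin-2-yl in place of isopropyl on a saturated chain carbon bound to an amide-type nitrogen The amide and the shared core are kept. Among the measured compounds shown here, no measured step of this kind exists, so the expectation rests on compound 2 alone and carries a wide range. A modest move toward a lower number is expected, a 1.5-fold lower number from compound 2 to compound 3 (0.18 log units; within the scatter), not clearly beyond the scatter. For compound 3 the estimate in this assay is 7000 nM, with a range from 2500 nM to 20000 nM.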

Compound 3, half-maximal inhibitory concentration: 15100 nM
Estimate against measurement, compound 3: 2.2-fold (0.33 log units) below; the range from low to high includes it.
By their numbers in this assay, from the lowest: compound 1; then compounds 2 and 3 (each within the scatter of the next).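

In this assay, pyridin-2-yl in place of isopropyl on a saturated chain carbon bound to an amide-type nitrogen gives a 1.4-fold higher number from compound 2 to compound 3 (0.15 log units; within the scatter) with the amide and the shared core kept, so compound 2 and compound 3 cannot be told apart. This position therefore accepts a six-membered aromatic ring with one hetero atom and one hydrogen-bond acceptor in place of isopropyl, without a step beyond the scatter. No measurement at hand bears on why this step is so small.

On these data alone, whether another group on this chain, such as an amine, a carboxylic acid or a longer chain, would give a step beyond the scatter remains open. Also open, as far as these compounds go, is what the ring nitrogen of pyridin-2-yl contributes, which phenyl at the same place would address.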